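Swapping the amide aryl: from quinoline to benzofuran

The compounds below may be only part of what the source reports. "The series", "measured", "known", "first", "only" and "open" are said of these compounds alone.

Measured compounds in a functional assay on HT-29 cells (Homo sapiens) for cytotoxicity, read by MTT assay, with a stated time of 72 h; a higher number here means a weaker inhibitor, a lower number a stronger inhibitor:
compound 1 `COc1ccc(C(=O)NC[C@H]2c3[nH]c4ccccc4c3C[C@H]3[C@H]4c5[nH]c6ccccc6c5C[C@@H]([C@H](C#N)N23)N4C)cc1` gives 840 nM
compound 2 `CN1[C@@H]2c3[nH]c4ccccc4c3C[C@H]1[C@H](C#N)N1[C@@H](CNC(=O)c3ccc4ccccc4c3)c3[nH]c4ccccc4c3C[C@@H]21` gives 4940 nM
compound 3 `CN1[C@@H]2c3[nH]c4ccccc4c3C[C@H]1[C@H](C#N)N1[C@@H](CNC(=O)c3ccc4ccccc4n3)c3[nH]c4ccccc4c3C[C@@H]21` gives 150 nM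

Compound 3 stands lowest of the three numbers; its nearest neighbour is compound 1 a 5.6-fold lower number from compound 1 to compound 3 (0.75 log units; beyond the scatter), and its furthest is compound 2 a 33-fold lower number from compound 2 to compound 3 (1.52 log units; beyond the scatter). Compound 4 `CN1[C@@H]2c3[nH]c4ccccc4c3C[C@H]1[C@H](C#N)N1[C@@H](CNC(=O)c3cc4ccccc4o3)c3[nH]c4ccccc4c3C[C@@H]21` has not yet been measured. The change from compound 3 to compound 4 is 1-benzofuran-2-yl in place of quinolin-2-yl on a carbonyl carbon.

Within the data shown here, two measured steps bear on this place. Both show that the group on the carbonyl carbon moves the number well beyond the scatter: a 5.9-fold higher number from compound 1 to compound 2 (0.77 log units; beyond the scatter) and a 5.6-fold lower number from compound 1 to compound 3 (0.75 log units; beyond the scatter). The bicyclic without a hetero atom, naphthalen-2-yl, gave the highest number, while quinolin-2-yl gave the lowest. The entering 1-benzofuran-2-yl keeps a fused bicyclic with one hydrogen-bond acceptor but in a five-membered ring. Compound 4 is therefore expected to lose some ground against compound 3, giving a modest rise, a 3.3-fold higher number from compound 3 to compound 4 (0.52 log units; beyond the scatter). Compound 4 is estimated at 500 nM, within a range of 150 nM to 2000 nM in this assay.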

Compound 4, half-maximal inhibitory concentration: 850 nM
Beside the measured number, compound 4's estimate is 1.7-fold (0.23 log units) below it, and the stated range covers the measured number.
By their numbers in this assay, from the lowest: compound 3; then compounds 1 and 4 (each within the scatter of the next); then compound 2.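

In this assay, 1-benzofuran-2-yl takes a place of its own among the fused bicyclic groups on this carbonyl carbon, separated from quinolin-2-yl (a 5.7-fold higher number from compound 3 to compound 4 (0.75 log units; beyond the scatter)) and from naphthalen-2-yl (a 5.8-fold lower number from compound 2 to compound 4 (0.76 log units; beyond the scatter)). The 4-methoxyphenyl of compound 1 and the 1-benzofuran-2-yl of compound 4 cannot be told apart (a 1.0-fold higher number from compound 1 to compound 4 (0.01 log units; within the scatter)), so a single aromatic ring and a fused pair of rings can read alike here, and having a fused bicyclic does not by itself fix the number. Nothing in the data given accounts for these differences.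

On these data alone, it remains open where an indol-2-yl or a 1-benzothiophen-2-yl group, each with a five-membered aromatic ring carrying another hetero atom, would fall. Every group shown on this carbonyl carbon is aromatic, so the effect of a saturated amine such as piperidine or of a carboxylic acid on a longer chain also remains unknown.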